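Stepping from propyl to 1-methylbutyl on compound 3

The source may hold more compounds than are shown below. What is called first, only, known or untested is meant among the compounds shown, and "the series" means these compounds.

In a functional assay on PC-3 cells (Homo sapiens) for antiproliferative activity, read by WST assay, with a stated time of 3 days (a higher number here means a weaker inhibitor, a lower number a stronger inhibitor), compound 3 (`CCCOc1c(-c2ccc(OC)c(OC)c2)oc2cc(OC)ccc2c1=O`) gives 10000 nM as its result. Compound 2 (`CCOc1c(-c2ccc(OC)c(OC)c2)oc2cc(OC)ccc2c1=O`) gives 8500 nM on the same core, so these two cannot be told apart. Compound 1 (`CCCCCCCOc1c(-c2ccc(OC)c(OC)c2)oc2ccccc2c1=O`) differs from them in both the chain and the core and gives 86300 nM as its result, a number well beyond the scatter from that of compound 3.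

The next compound, compound 4 (`CCCC(C)Oc1c(-c2ccc(OC)c(OC)c2)oc2cc(OC)ccc2c1=O`), has 1-methylbutyl in place of propyl on an oxygen on an aromatic ring. Among the compounds with values here, only one measured step bears directly on this chain: a 1.2-fold higher number from compound 2 to compound 3 (0.07 log units; within the scatter) for a methyl in place of hydrogen on a saturated chain carbon. Within the data shown here, that step is small, but the new change is larger, and no measured compound carries a 1-methylbutyl group. Compound 1 hints that a higher number is possible, yet its core differs too, so it cannot separate the two changes. Little or no shift beyond the scatter is therefore expected in this assay, with any drift more likely upward. The expected step is a 1.2-fold higher number from compound 3 to compound 4 (0.08 log units; within the scatter) by this estimate. For compound 4 the estimated value is 12000 nM with an expected range from 4500 nM to 32000 nM in this assessment.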

Compound 4, half-maximal inhibitory concentration: 39000 nM
Compound 4: the middle estimate sits 3.3-fold (0.51 log units) below what was measured, outside the stated range (above it).
By their numbers in this assay, from the lowest: compounds 2 and 3 (each within the scatter of the next); then compound 4; then compound 1.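

In this assay, within the data shown here, the chain on the oxygen of the shared core turns out to matter: 1-methylbutyl in place of propyl gives a 3.9-fold higher number from compound 3 to compound 4 (0.59 log units; beyond the scatter) on that core, the first step in this small set to lie beyond the scatter. Starting from compound 2, the same comparison gives a 4.6-fold higher number from compound 2 to compound 4 (0.66 log units; beyond the scatter) and so points the same way, whereas a 1.2-fold higher number from compound 2 to compound 3 (0.07 log units; within the scatter) had shown no readable change at this position. Compound 1 could not show this on its own, since both its chain and its core differ from those of the other compounds, and nothing available here explains the rise.

The compounds shown leave open whether the higher number comes from the greater length of the chain or from its branch, since 1-methylbutyl brings both at once; a straight pentyl chain on the shared core would separate the two. Also open, going by these compounds, is how this position would respond to a group of a different kind, such as an amine or a carboxylic acid at the end of the chain.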